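Adding a third methoxy to compound 3

This account rests on a few compounds, and the source may have more. Where it says the series, first, only, none or still open, it means among the compounds named here.

Measured so far in a functional assay on LoVo cells (Homo sapiens) for inhibition, read by MTT assay, with a stated time of 72 h (a lower number here means a stronger inhibitor, a higher number a weaker inhibitor), are these compounds
- compound 1 `COc1cc(NC(=O)/C=C/c2cccc(OCc3ccccc3)c2)cc(OC)c1OC` gives 21700 nM
- compound 2 `C=C(Br)C(=O)Nc1cccc(/C=C/C(=O)Nc2ccc(OC)c(OC)c2)c1` gives 150 nM
- compound 3 `C=C(Br)C(=O)Nc1cccc(/C=C/C(=O)Nc2cc(OC)cc(OC)c2)c1` gives 1210 nM

Compound 3 at 1210 nM stands second highest of the three numbers in this assay with compound 2 lower and compound 1 higher, both gaps beyond the scatter. Compound 4 `C=C(Br)C(=O)Nc1cccc(/C=C/C(=O)Nc2cc(OC)c(OC)c(OC)c2)c1` is still unmeasured. It departs from compound 3 by methoxy in place of hydrogen on an aromatic carbon, ortho to two methoxy groups and para to a large group, counted in full as methoxy in place of hydrogen on an aromatic carbon here.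

Going by the values given here, no measured pair differs in one place only, so this change has no direct precedent. The guide is indirect. Compound 2 at 150 nM shows that a number well under that of compound 3 is reachable in this set, while compound 1 at 21700 nM differs too much to guide the estimate. A moderate fall is expected, not a rise, and the estimated size is a 2.7-fold lower number from compound 3 to compound 4 (0.43 log units; beyond the scatter) with wide uncertainty. Compound 4 is estimated at 450 nM with an expected range from 120 nM to 1600 nM on this reading.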

Compound 4, half-maximal inhibitory concentration: 140 nM
Compound 4: the middle estimate sits 3.2-fold (0.51 log units) above what was measured; the measured number falls inside the stated range.
By their numbers in this assay, from the lowest: compounds 4 and 2 (each within the scatter of the next); then compound 3; then compound 1.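

In this assay, going by these compounds alone, methoxy in place of hydrogen on the aromatic carbon ortho to two methoxy groups and para to a large group gives an 8.6-fold lower number from compound 3 to compound 4 (0.94 log units; beyond the scatter), the first direct reading of a change at this position. The same kind of change starting from compound 2 gives a 1.1-fold lower number from compound 2 to compound 4 (0.03 log units; within the scatter), so among these compounds, the effect of adding a methoxy depends on which methoxy groups the ring already carries. With the trimethoxy pattern held in both compounds, ((1-bromoethenyl)carbonyl)amino in place of benzyloxy gives a 160-fold lower number from compound 1 to compound 4 (2.19 log units; beyond the scatter), a much larger step than either methoxy change. Nothing available here accounts for these steps.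

The compounds shown leave open whether a hydroxyl, an ethoxy or an amine at this position would match the methoxy of compound 4, or whether methoxy is specifically needed there. They also leave open how much of the step from compound 1 belongs to the bromine, which a chlorine or a plain ethenyl carbonyl amino group in the same place would begin to separate.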